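A few compounds are considered here, and "the series" means these few. Any claim that something is new, unique, unknown or untested is made for them only; others in the source may bear on it.

Compound 1 `COC(=O)/C=C/c1cccc(N(Cc2ccc(-c3cccc(C)c3)cc2)C(=O)C2CCCCC2)c1` gives the lowest of the three numbers in an assay on isolated protein with Bile acid receptor (Homo sapiens) as the target (on this read-out lower numbers stand for an effect already at smaller amounts and higher numbers for an effect only at larger amounts of compound), with compound 1 at 109 nM. Compound 2 `COC(=O)/C=C/c1cccc(N(Cc2ccc(-c3cccc(C)c3)cc2)C(=O)C(C)C)c1` sits close by, as compound 2 gives 163 nM in this assay, and the move was a 1.5-fold higher number from compound 1 to compound 2 (0.17 log units; within the scatter). Compound 3 `COC(=O)/C=C/c1cccc(N(Cc2ccc(-c3cccc(OC(F)(F)F)c3)cc2)C(=O)C(C)C)c1` gives 247 nM, a change of a 1.5-fold higher number from compound 2 to compound 3 (0.18 log units; within the scatter); the gap between compound 1 and compound 3 is the only one beyond the scatter.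

Compound 4 `COC/C=C/c1ccc(CN(C(=O)C2CCCCC2)c2cccc(/C=C/C(=O)OC)c2)cc1` differs from compound 1 in a single place: 3-methoxyprop-1-en-1-yl in place of 3-methylphenyl on an aromatic carbon. Going by the values given here, none of the measured steps is of this kind. The change from compound 2 to compound 3 touches the same ring but only swaps one substituent on it, whereas here the whole ring leaves and an open chain enters; the change from compound 1 to compound 2 concerns a different part of the molecule. Both of those steps stayed within the scatter. With a ring removed, a somewhat weaker result is expected, so the step is estimated as a 2.8-fold higher number from compound 1 to compound 4 (0.44 log units; beyond the scatter). Compound 4 is expected to give 300 nM in this assay, with a range from 120 nM to 900 nM.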

Compound 4, half-maximal effective concentration: 233 nM
Estimate against measurement, compound 4: 1.3-fold (0.11 log units) above; the measured number falls inside the stated range.
By their numbers in this assay, from the lowest: compounds 1, 2, 4 and 3 (each within the scatter of the next, the first and the last beyond it).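

Compound 4 gives the first step read at this position, on an aromatic carbon para to a large group: taking out 3-methylphenyl and putting in 3-methoxyprop-1-en-1-yl gives a 2.1-fold higher number from compound 1 to compound 4 (0.33 log units; beyond the scatter) in this assay. The six-membered aromatic ring is thus not needed there for a measurable effect, since compound 4, with an open chain in its place, still gives 233 nM, although the change costs more than the scatter allows. Nothing available explains this step.

As far as these compounds go, it stays open whether the step follows from the ring leaving or from the oxygen entering with the chain, and how a saturated methoxypropyl chain or a chain ending in a dimethylamino group would read at this position. From the compounds shown here alone, whether the step carries over when isopropyl replaces cyclohexyl on the carbonyl carbon also remains open.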